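From cyclopropylamino to dimethylamino on the carbonyl carbon

The source may hold more compounds than are shown below. What is called first, only, known or untested is meant among the compounds shown, and "the series" means these compounds.

Compound 1 `O=C(/C=C/c1ccncc1-c1ccc2ccccc2c1)NC1CC1` was tested in a functional assay on MDA-MB-231 cells (Homo sapiens) for inhibition, read by sulforhodamine B assay, with a stated time of 72 h (on this read-out higher numbers stand for weaker inhibition of growth and lower numbers for stronger inhibition of growth), where compound 1 gives 8420 nM. Of the two compounds with a numerical value this is the higher, but compound 3 `CNC(=O)/C=C/c1ccncc1-c1ccc2cc[nH]c2c1`, which gives 7680 nM in this assay, sits within the usual scatter of compound 1, so the two cannot be told apart. Compound 2 `O=C(CCc1ccncc1-c1ccc2ccccc2c1)N1CCOCC1` returns only a limit of the method in this assay, > 10000 nM; (the limit of > 10000 nM in this assay, at which 1 of the 3 values shown sits). Compound 4 `CN(C)C(=O)/C=C/c1ccncc1-c1ccc2ccccc2c1` has not yet been measured. It differs from compound 1 in one place (dimethylamino in place of cyclopropylamino on a carbonyl carbon). Within the data shown here, no pair of measured compounds that differ in a single place is available, so the step has to be judged from the three values alone, all of which sit near or beyond the top of the measurable range. Since compound 1 gives 8420 nM, compound 4 is expected to give 12000 nM in this assay, within a range from 5000 nM to 30000 nM. This means an expected step of a 1.4-fold higher number from compound 1 to compound 4 (0.15 log units; within the scatter), small, with a real chance that the assay reports only a limit.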

Compound 4, concentration for 50% growth inhibition: 7990 nM
Compound 4: middle estimate off by 1.5-fold (0.18 log units), on the high side; measured number inside the range.
By their numbers in this assay, from the lowest: compounds 3, 4 and 1 (each within the scatter of the next). At a limit, above all of these: compound 2.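

Among these compounds, this is the first comparison that changes a single place, and in this assay the step reads a 1.1-fold lower number from compound 1 to compound 4 (0.02 log units; within the scatter). The amide hydrogen and the three-membered ring of cyclopropylamino both leave with this change, yet the number does not move beyond the scatter, so at this carbonyl carbon neither one is needed to hold the value at this level. The measurements give no cause for this flat step.

As far as these compounds go, whether a primary amide, a piperidine amide or a carboxylic acid on this carbonyl carbon would give a number beyond the scatter remains open. From the compounds shown here alone, it is also open whether any group in this place can bring the number well down, as both amides compared here remain close to the top of the measurable range.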